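The compounds below may be only part of what the source reports. "The series", "measured", "known", "first", "only" and "open" are said of these compounds alone.

In a functional assay on MDA-MB-468 cells (Homo sapiens) for antiproliferative activity, read by sulforhodamine B assay, with a stated time of 48 h (a lower number here means a stronger inhibitor, a higher number a weaker inhibitor), the measured compounds are:
compound 1 `COc1ccc(-c2nsc3c2NC(=O)CC3c2ccc3c(c2)OCCO3)cc1` with 328 nM;
compound 2 `COc1ccc(-c2nsc3c2NC(=O)CC3c2cccc(Cl)c2)cc1` with 174 nM;
compound 3 `COc1ccc(-c2nsc3c2NC(=O)CC3c2cccc(F)c2)cc1` with 1940 nM.

Compound 3 stands at the highest number of the three. Among the compounds with values here, its nearest neighbour is compound 1 and its furthest is compound 2, and the single measured step, an 11-fold higher number from compound 2 to compound 3 (1.05 log units; beyond the scatter), is large: it shows that the ring attached to the saturated ring carbon of the shared core changes the outcome considerably.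

Compound 4 `COc1ccc(-c2nsc3c2NC(=O)CC3c2ccsc2)cc1` has not yet been measured. It differs from compound 3 in one place: thiophen-3-yl in place of 3-fluorophenyl on a saturated ring carbon. The entering ring is the smaller one, with one hetero atom and one hydrogen-bond acceptor where the leaving ring had none.

Within the data shown here, no measured step contains a thiophen-3-yl ring, so the direction of this change cannot be read from a matching pair. What the data do show is that both other groups tried at this position, in compound 2 and compound 1, gave lower numbers than compound 3, and that the step of an 11-fold higher number from compound 2 to compound 3 (1.05 log units; beyond the scatter) was large. On that basis a step toward a lower number is expected, a 2.8-fold lower number from compound 3 to compound 4 (0.44 log units; beyond the scatter), with wide uncertainty. Compound 4 is therefore estimated at 700 nM, within a range from 200 nM to 2500 nM.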

Compound 4, half-maximal inhibitory concentration: 117 nM
For compound 4 the middle estimate is 6.0-fold (0.78 log units) above the measured one, outside the stated range (below it).
By their numbers in this assay, from the lowest: compounds 4, 2 and 1 (each within the scatter of the next, the first and the last beyond it); then compound 3.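

In this assay the saturated ring carbon accepts a five-membered aromatic ring with a sulfur atom, and a six-membered aromatic ring of carbon only is therefore not required there: thiophen-3-yl in place of 3-fluorophenyl gives a 17-fold lower number from compound 3 to compound 4 (1.22 log units; beyond the scatter) as a large change. Thiophen-3-yl in place of 3-chlorophenyl gives a 1.5-fold lower number from compound 2 to compound 4 (0.17 log units; within the scatter) and so leaves the two compounds indistinguishable, even though the entering ring is the smaller one and carries a hetero atom. The high number of compound 3 is thus a feature of the 3-fluorophenyl ring rather than of this position as a whole, since the thiophen-3-yl, 3-chlorophenyl and fused dioxane-bearing rings of the other three compounds all give lower numbers.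

The compounds shown offer no measurement that accounts for the gap between the 3-fluorophenyl ring and the other rings. From the compounds shown here alone, it also remains open how this carbon would respond to a furan ring, a pyridine ring or a cyclohexyl ring, or to a ring carrying an amine or a carboxylic acid.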